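The source may hold more compounds than are shown below. What is called first, only, known or untested is meant among the compounds shown, and "the series" means these compounds.

Three compounds built on a shared core differ only in the aromatic group at one end. Compound 1 `Cc1cccc(-c2noc([C@H](C)NC(=O)c3cc(C(F)(F)F)nn3C)n2)n1` carries 6-methylpyridin-2-yl; in an assay on T-REx-293 cells for inhibition of potassium channel subfamily T member 1 (Homo sapiens), read by patch clamp (on this read-out lower numbers stand for stronger inhibition and higher numbers for weaker inhibition), compound 1 gives only a limit, > 30000 nM, and no number. This is the ceiling of the assay, (the limit of > 30000 nM in this assay, at which 1 of the 3 values shown sits). Compound 2 `Cc1ccnc(-c2noc([C@H](C)NC(=O)c3cc(C(F)(F)F)nn3C)n2)c1` carries 4-methylpyridin-2-yl and gives 4470 nM in this assay. Compound 3 `C[C@H](NC(=O)c1cc(C(F)(F)F)nn1C)c1nc(-c2ccncc2)no1` carries pyridin-4-yl and gives 5250 nM. Of the two real numbers compound 3 holds the higher one, yet its gap to compound 2, a 1.2-fold higher number from compound 2 to compound 3 (0.07 log units; within the scatter), lies within the scatter. The two changes away from 6-methylpyridin-2-yl gave an at least 6.7-fold lower number from compound 1 to compound 2 (0.82 log units; beyond the scatter) and an at least 5.7-fold lower number from compound 1 to compound 3 (0.75 log units; beyond the scatter), so the pattern on this ring can move the number by a modest amount, or, as between compound 2 and compound 3, leave it unchanged.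

Compound 4 `C[C@H](NC(=O)c1cc(C(F)(F)F)nn1C)c1nc(-c2ccnc(N3CCCC3)c2)no1` is compound 3 with pyrrolidin-1-yl in place of hydrogen on an aromatic carbon. For the measured compounds named here, no measured step adds a group of this kind to the ring, so the three steps only set the scale of what such a change has done so far. A shift of that size in either direction, or none at all, is possible. The estimate leans to a small gain, a 1.8-fold lower number from compound 3 to compound 4 (0.24 log units; within the scatter). Compound 4 is therefore expected at 3000 nM, between 700 nM and 13000 nM.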

Compound 4, half-maximal inhibitory concentration: 573 nM
The estimate for compound 4 lay 5.2-fold (0.72 log units) above the measured number, and the stated range ends above it.
By their numbers in this assay, from the lowest: compound 4; then compounds 2 and 3 (each within the scatter of the next). At a limit, above all of these: compound 1.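

In this assay, putting pyrrolidin-1-yl in place of hydrogen on the pyridin-4-yl ring gives a 9.2-fold lower number from compound 3 to compound 4 (0.96 log units; beyond the scatter), a change that lies beyond the scatter. The earlier compounds shown here only showed what happens when the ring's attachment pattern and a methyl group vary, and compound 2 and compound 3 could not be told apart. This step shows something new: the aromatic carbon next to the ring nitrogen can carry a much larger group, a five-membered non-aromatic ring joined through its nitrogen, and inhibition becomes stronger rather than being lost.

A single substituent at a single position cannot show whether the gain belongs to pyrrolidin-1-yl in particular, so an open-chain amine such as dimethylamino, a morpholine ring, or a simple methyl group on this same carbon would be needed to separate the ring from the attached nitrogen. It also remains open how far a larger ring, such as piperidine, would carry the trend, and no measurement shown here accounts for why this group has the effect it does.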